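Two chlorines on the sulfonyl-linked phenyl ring

The compounds below may be only part of what the source reports. "The series", "measured", "known", "first", "only" and "open" are said of these compounds alone.

Of the compounds shown here, three sharing one core have been measured in a functional assay on HeLa cells for agonist activity at 5-hydroxytryptamine receptor 6 (Homo sapiens), read by cAMP accumulation and immunoassay; on this read-out higher numbers stand for larger maximal responses and lower numbers for smaller maximal responses. Compound 1 `O=S(=O)(c1ccccc1Cl)c1cn(C2CCCNC2)c2ncccc12` gives 84%. Compound 2 `O=S(=O)(c1cccc(Br)c1)c1cn(C2CCCNC2)c2ncccc12` gives 49%, and compound 3 `O=S(=O)(c1cccc(F)c1)c1cn(C2CCCNC2)c2ncccc12` gives 84%. Compound 3 thus stands level with compound 1 at the digits shown, the two together forming the top of the three numbers, while compound 2 lies well beneath them: the change from a number 35 percentage points higher from compound 2 to compound 3 (beyond the scatter) is large, as is the change from a number 35 percentage points lower from compound 1 to compound 2 (beyond the scatter), whereas no change at the digits printed from compound 1 to compound 3 (within the scatter).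

Compound 4 `O=S(=O)(c1cc(Cl)cc(Cl)c1)c1cn(C2CCCNC2)c2ncccc12` has not yet been measured. It differs from compound 3 in one place: 3,5-dichlorophenyl in place of 3-fluorophenyl on a sulfonyl sulfur.

For the measured compounds named here, the step that bears most on this is the one between compound 2 and compound 3, where fluoro in place of bromo on the aromatic carbon raised the response by a number 35 percentage points higher from compound 2 to compound 3 (beyond the scatter). Chloro is a different halogen again, and compound 4 carries two of them on that ring, so the drop seen with bromo argues that the response is expected to fall rather than rise. Compound 4 is therefore estimated at 60%, with a range from 40% to 85%, an expected change of a number 24 percentage points lower from compound 3 to compound 4 (beyond the scatter).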

Compound 4, largest response reached (Emax), in percent of the reference or control that the assay uses: 62%
Compound 4: the middle estimate sits 2 percentage points below what was measured; low and high end bracket the measured number.
By their numbers in this assay, from the lowest: compound 2; then compound 4; then compounds 1 and 3 (each within the scatter of the next).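

In this assay, 3,5-dichlorophenyl in place of 3-fluorophenyl on the sulfonyl sulfur gives a number 22 percentage points lower from compound 3 to compound 4 (beyond the scatter), and the comparison with the 2-chlorophenyl group gives a number 22 percentage points lower from compound 1 to compound 4 (beyond the scatter). Set against the 3-bromophenyl group, the same 3,5-dichlorophenyl group gives a number 13 percentage points higher from compound 2 to compound 4 (beyond the scatter), so the change runs the other way here. The earlier compounds shown here showed only two levels, with two compounds at the top and one far beneath them, whereas this group gives an intermediate response, so the aryl group on the sulfonyl sulfur can set the maximal response at more than those two levels.

Nothing available explains why these four aryl groups rank as they do. Still open, going by these compounds, is how the response would change with an unsubstituted phenyl ring on the sulfonyl sulfur, or with a ring carrying a methoxy group, an amine or a carboxylic acid instead of halogen, and so whether the levels seen here are tied to halogens at all.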